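Moving a halogen around the phenyl ring of compound 2

The source may report more compounds than this note shows. Statements on the series, on what has been measured and on what is new or still open speak of the compounds shown alone.

In a functional assay on the whole organism with Mus musculus as the target, in the maximal electroshock model, with a stated time of 4 h (a higher number here means that more compound is needed for the effect, a lower number that less compound is needed), compound 2, `SC1=NC(n2nc(-c3ccccc3)nc2-c2ccccc2)=CC(c2ccccc2Cl)N1`, gives 300 mg/kg. Its closest neighbour is compound 1, `SC1=NC(n2nc(-c3ccccc3)nc2-c2ccccc2)=CC(c2ccc(Cl)cc2)N1`, which in this assay gives 300 mg/kg; the step of no change at the digits printed from compound 1 to compound 2 (within the scatter) lies within the scatter. A third compound, compound 3, `O=[N+]([O-])c1cccc(C2C=C(n3cc(-c4ccccc4)nc3-c3ccccc3)N=C(S)N2)c1`, also gives 300 mg/kg in this assay, so all three measured values stand level at the digits shown.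

Compound 4 is `SC1=NC(n2nc(-c3ccccc3)nc2-c2ccccc2)=CC(c2ccc(Br)cc2)N1`. Its change from compound 2 is 4-bromophenyl in place of 2-chlorophenyl on a saturated ring carbon. Going by the values given here, the one measured step that bears on it, no change at the digits printed from compound 1 to compound 2 (within the scatter), exchanged a 4-chlorophenyl for a 2-chlorophenyl on the same saturated ring carbon and brought no change beyond the scatter, and the 4-bromophenyl of compound 4 is, like these two groups, a single halogen on a phenyl ring. Among the compounds with values here, no step in which a bromine replaced a chlorine has been measured here. The expected step is therefore no change at the digits printed from compound 2 to compound 4 (within the scatter), none beyond the scatter. In this assay compound 4 is estimated at 300 mg/kg, with a range from 150 mg/kg to 600 mg/kg.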

Compound 4, minimum effective dose: 300 mg/kg
Estimate against measurement, compound 4: no gap at the digits printed; the measured number falls inside the stated range.
By their numbers in this assay, from the lowest: compounds 1, 2, 3 and 4 (each within the scatter of the next).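

Going by these compounds alone, compound 4 gives the first measured exchange of one halogen for another on the phenyl ring at this saturated ring carbon: bromo in place of chloro shows no change at the digits printed from compound 1 to compound 4 (within the scatter) in this assay. Changing the halogen and its place on the ring together shows no change at the digits printed from compound 2 to compound 4 (within the scatter), so among compounds 1, 2 and 4 neither change moves the minimum effective dose beyond the scatter. No measured information is available to explain this flat result.

The compounds shown leave open whether a phenyl ring carrying an amine or a methoxy group instead of a halogen would give a different dose in this assay. They also leave open what a plain ethyl chain in place of the whole phenyl ring would do at this carbon.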